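Sulfonamide Enaminone Coumarins Against T47D Cells

This account rests on a few compounds, and the source may have more. Where it says the series, first, only, none or still open, it means among the compounds named here.

Measured compounds:
compound 1 `CN(C)/C=C/C(=O)c1cc2ccccc2oc1=O` 147000 nM
compound 2 `Cc1cc(NS(=O)(=O)c2ccc(N/C=C\C(=O)c3cc4ccccc4oc3=O)cc2)on1` 75600 nM

In a functional assay on T47D cells (Homo sapiens) for cytotoxicity, read by sulforhodamine B assay, with a stated time of 48 h (a lower number here means a stronger inhibitor, a higher number a weaker inhibitor), compound 1 gives 147000 nM and compound 2 gives 75600 nM. Compound 2 holds the lowest of the two numbers, yet its gap to compound 1 falls within the scatter, so no order between them can be stated. Compound 3 `Cc1ccnc(NS(=O)(=O)c2ccc(N/C=C\C(=O)c3cc4ccccc4oc3=O)cc2)n1` is not yet measured; it differs from compound 2 by 4-methylpyrimidin-2-yl in place of 3-methyl-1,2-oxazol-5-yl on a sulfonamide nitrogen. For the measured compounds named here, no measured pair shows this kind of change, so nothing beyond the scatter is expected: the step of a 1.1-fold lower number from compound 2 to compound 3 (0.03 log units; within the scatter) is estimated as flat. Compound 3 is therefore expected to give about 70000 nM, with a range from 25000 nM to 200000 nM.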

Compound 3, half-maximal inhibitory concentration: 24500 nM
Beside the measured number, compound 3's estimate is 2.9-fold (0.46 log units) above it; measured number below the stated range.
By their numbers in this assay, from the lowest: compound 3; then compounds 2 and 1 (each within the scatter of the next).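

In this assay the group on a sulfonamide nitrogen is shown to matter: 4-methylpyrimidin-2-yl in place of 3-methyl-1,2-oxazol-5-yl gives a 3.1-fold lower number from compound 2 to compound 3 (0.49 log units; beyond the scatter) as a modest step, the only one here beyond the scatter. The number at this position can therefore move while the rest of the molecule stays the same. Nothing shown accounts for the step. Still open, as far as these compounds go, is whether a plain pyrimidin-2-yl or a 4,6-dimethylpyrimidin-2-yl on that nitrogen would go further, and whether the methyl on the pyrimidine contributes at all.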